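The source may report more compounds than this note shows. Statements on the series, on what has been measured and on what is new or still open speak of the compounds shown alone.

Measured so far:
Compound 1, `CCOC(=O)[C@H](CCC(=O)O)NC(=O)c1ccc(CNc2nc3cc(N)cc(N)c3nc2-c2ccccc2)cc1`: in a functional assay on MOLT-4 cells (Homo sapiens) for inhibition, read by sulforhodamine B assay, with a stated time of 48 h (on this read-out higher numbers stand for weaker inhibition of growth and lower numbers for stronger inhibition of growth), compound 1 gives 9770 nM.
Compound 2, `COc1cc(CNc2nc3cc(N)cc(N)c3nc2-c2ccccc2)cc(OC)c1OC`: in this assay compound 2 gives < 50200 nM, which is a limit of the assay, not a number.
Compound 3, `COc1ccc(Sc2nc3cc(N)cc(N)c3nc2-c2ccccc2)cc1`: in this assay compound 3 gives < 100000 nM, which is also a limit of the assay, not a number.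

Among the measured compounds shown here, compound 3 therefore stands at a limit (the limit of < 100000 nM in this assay, at which 1 of the 3 values shown sits), compound 2 at another limit (the limit of < 50200 nM in this assay, at which 1 of the 3 values shown sits), and only compound 1 carries a number; no step between measured compounds can be read from this. Compound 4, `Nc1cc(N)c2nc(-c3ccccc3)c(Sc3ccc(F)cc3)nc2c1`, differs from compound 3 by fluoro in place of methoxy on an aromatic carbon. With compound 3 known only as a limit, no direction beyond the scatter can be set for this change. Compound 4 is expected to give 30000 nM, with a range from 5000 nM to 100000 nM. That estimate means an expected step that the limit leaves unreadable from compound 3 to compound 4.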

Compound 4, concentration for total growth inhibition: < 100000 nM
Compound 4 gave a limit, no number (the forecaster's own chance of this, stated with the estimate: 40%); the middle value is on the limit's open side.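

Among the compounds shown here, compound 3 and compound 4 both stand at a limit of this assay, not at a number, and no step between them can be read. The compounds shown leave open whether fluoro in place of methoxy changes growth inhibition at all.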